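A few compounds are considered here, and "the series" means these few. Any claim that something is new, unique, unknown or untested is made for them only; others in the source may bear on it.

Compound 1 `O=C(Nc1cc(-c2nc3ccccc3o2)ccc1F)c1cc([N+](=O)[O-])ccc1Cl` was tested in an ADME assay on BJ cells (Homo sapiens) for cytotoxicity, with a stated time of 72 h (a lower number here means that less compound is needed, a higher number that more compound is needed for the effect), and gave > 25000 nM, which is a limit of the assay rather than a number. Compound 2 `O=C(Nc1nc2ccc(F)cc2s1)c1cc([N+](=O)[O-])ccc1Cl` likewise reached only a limit in this assay, at > 27000 nM. Compound 3 `O=C(Nc1cc(-c2nc3ccccc3s2)ccc1F)c1cc([N+](=O)[O-])ccc1Cl` also stopped at a limit in this assay, giving > 25000 nM. The step that the two limits leave unreadable from compound 1 to compound 3 therefore cannot be read, because the limit of > 25000 nM in this assay, at which 2 of the 3 values shown sit, marks where both compounds sit. Compound 4 `COc1ccc(-c2nc3ccccc3o2)cc1NC(=O)c1cc([N+](=O)[O-])ccc1Cl` differs from compound 1 by methoxy in place of fluoro on an aromatic carbon. Going by the values given here, no measured step resembles this change, and every value so far is a limit, as the limit of > 25000 nM in this assay, at which 2 of the 3 values shown sit, and the limit of > 27000 nM in this assay, at which 1 of the 3 values shown sits, show. Compound 4 is therefore expected to stay at the limit as well, with an estimated 30000 nM (range 12000 nM to 80000 nM). The expected step that the limit leaves unreadable from compound 1 to compound 4 is thus one of no readable size.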

Compound 4, half-maximal effective concentration: > 25000 nM
Compound 4 gave a limit, no number (the forecaster's own chance of this, stated with the estimate: 80%); the middle value does not contradict the limit.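

Going by these compounds alone, compound 4 gave > 25000 nM in this assay, a limit and not a number, and compound 1 also stopped at a limit, so no step between them can be read. On these data alone, how much of compounds 1 to 4 the effect would need, and whether methoxy in place of fluoro changes that, stays open.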